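A few compounds are considered here, and "the series" means these few. Any claim that something is new, unique, unknown or untested is made for them only; others in the source may bear on it.

Of the compounds shown here, three sharing one core have been measured in an ADME assay on the whole organism with Rattus norvegicus as the target; a higher number here means that the compound lasts longer, a lower number that the compound disappears faster. Compound 1 `O=C1NC=C(C(=O)NCCCN2CCC(c3ccc(F)cc3)CC2)[C@@H](c2ccc(F)c(F)c2)N1` gives 1 h. Compound 2 `CC1=C(C(=O)NCCCN2CCC(c3ccc(F)cc3)CC2)[C@@H](c2ccc(F)c(F)c2)NC(=O)N1` gives 1.7 h. Compound 3 `CC1=C(C(=O)NCCCN2CCC(c3ccc(F)cc3C#N)CC2)[C@@H](c2ccc(F)c(F)c2)NC(=O)N1C` gives 2.2 h. How the core of compound 3 differs from that of compound 2 is not broken down here. The change from compound 2 to compound 1 is hydrogen in place of methyl on a double-bonded ring carbon and it produced a 1.7-fold lower number from compound 2 to compound 1 (0.23 log units; within the scatter). Compound 4 `CN1C=C(C(=O)NCCCN2CCC(c3ccc(F)cc3C#N)CC2)[C@@H](c2ccc(F)c(F)c2)NC1=O` has not yet been measured in this assay. It differs from compound 3 by hydrogen in place of methyl on a double-bonded ring carbon, the same kind of change, though here the place is also next to the ring atom that bears a methyl group. Because of a 1.7-fold lower number from compound 2 to compound 1 (0.23 log units; within the scatter) a similar step is expected: a 1.7-fold lower number from compound 3 to compound 4 (0.23 log units; within the scatter). Compound 4 is therefore estimated at 1.3 h, between 0.7 h and 2.5 h.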

Compound 4, half-life: 0.8 h
Compound 4: middle estimate off by 1.6-fold (0.21 log units), on the high side, and the stated range covers the measured number.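

In this assay, hydrogen in place of methyl on a double-bonded ring carbon gave a 2.8-fold lower number from compound 3 to compound 4 (0.44 log units; beyond the scatter). Set beside the earlier step, this one cannot be told apart from it: the same change on two cores in this assay, a 1.7-fold lower number (0.23 log units; within the scatter) from compound 2 to compound 1 and a 2.8-fold lower number (0.44 log units; beyond the scatter) from compound 3 to compound 4, 1.6-fold (0.21 log units) apart, within the scatter of two such steps. The change therefore carries from one core to the other with a size that stays within the scatter of such a comparison, but only two cores are shown, the earlier step alone does not exceed the scatter, and nothing here explains the steps or establishes a rule for the whole series.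

The compounds shown leave open what an ethyl group, a longer chain or an amine on that ring carbon would give in this assay. They also leave open whether the step would be similar on other cores.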